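A few compounds are considered here, and "the series" means these few. Any claim that something is new, unique, unknown or untested is made for them only; others in the source may bear on it.

Three compounds share one core. Compound 1 `CC(Sc1nnc(-c2ccncc2)s1)C(=O)Nc1ccccc1Cl` carries a 2-chlorophenyl on an amide-type nitrogen, and in an ADME assay on BHK-21 cells (Mesocricetus auratus) for cytotoxicity, with a stated time of 3 days (on this read-out lower numbers stand for higher toxicity in this test and higher numbers for lower toxicity in this test), compound 1 gives > 50000 nM, which is a limit of the assay and not a measured number. Compound 2 `CC(Sc1nnc(-c2ccncc2)s1)C(=O)NCc1ccccc1Cl` bears a 2-chlorobenzyl on that nitrogen instead; in this assay compound 2 gives > 50000 nM, again a limit. The step that the two limits leave unreadable from compound 1 to compound 2 therefore cannot be sized. Compound 3 `CC(Sc1nnc(-c2ccncc2)s1)C(=O)NCc1ccc(Cl)cc1`, with a 4-chlorobenzyl on the same nitrogen, has "not determined" (no result reported) in this assay, so no number places it on the scale. Compound 4 `CC(Sc1nnc(-c2ccncc2)s1)C(=O)Nc1c(Cl)cccc1Cl` differs from compound 3 by 2,6-dichlorophenyl in place of 4-chlorobenzyl on an amide-type nitrogen. No measured step bears directly on this change, and the one step shown is unreadable. For the measured compounds named here, the only guide is the limit of > 50000 nM in this assay, at which 2 of the 3 values shown sit, which makes a further limit the most likely outcome, with no direction that can be read. Compound 4 is therefore expected to give about 60000 nM in this assay, within a range from 20000 nM to 200000 nM, most probably reported only as a limit.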

Compound 4, half-maximal cytotoxic concentration: > 50000 nM
Compound 4 ended at the assay's limit (the forecaster's own chance of this, stated with the estimate: 80%); the middle value does not contradict the limit.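

For the compounds shown here, compound 1, compound 2 and compound 4 all end at a limit and not at a measured number, so no step among them can be read: the limit of > 50000 nM in this assay, at which 3 of the 4 values shown sit.

The compounds shown leave open whether any change on the amide-type nitrogen shifts the result in this assay at all, and where compound 3 stands.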